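The source may hold more compounds than are shown below. What is called first, only, known or untested is meant among the compounds shown, and "the series" means these compounds.

Compound 1 `Cc1cc(=O)c2c(O)cc(OCc3ccccc3)c([C@H]3CCN(C)C[C@H]3O)c2o1`: 41%
Compound 2 `COc1ccc(COc2cc(O)c3c(=O)cc(C)oc3c2[C@H]2CCN(C)C[C@H]2O)cc1`: 35%
Compound 3 `Cc1cc(=O)c2c(O)cc(OCc3ccc([N+](=O)[O-])cc3)c([C@H]3CCN(C)C[C@H]3O)c2o1`: 23%

Of the compounds shown here, three sharing one core have been measured in a functional assay on PC-3 cells (Homo sapiens) for inhibition, read by MTT assay, with a stated time of 48 h, tested at 10 uM; a lower number here means less inhibition of growth, a higher number more inhibition of growth at the concentration tested. Compound 1 carries a benzyloxy group on the core and gives the highest of the three numbers in this assay. Compound 2 differs from it by a methoxy in place of hydrogen on an aromatic carbon, and the step of a number 6 percentage points lower from compound 1 to compound 2 (within the scatter) lies within the scatter. Compound 3 carries a nitro in place of hydrogen on an aromatic carbon, and the step of a number 18 percentage points lower from compound 1 to compound 3 (beyond the scatter) is beyond the scatter; between compound 2 and compound 3 the step of a number 12 percentage points lower from compound 2 to compound 3 (beyond the scatter) is also beyond the scatter.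

Compound 4 `Cc1cc(=O)c2c(O)cc(OCc3ccco3)c([C@H]3CCN(C)C[C@H]3O)c2o1` has not yet been measured. It differs from compound 1 by furan-2-yl in place of phenyl on a saturated chain carbon bound to an oxygen on an aromatic ring. Within the data shown here, none of the measured steps touches the ring itself: they change what sits on the phenyl, and the two changes that went beyond the scatter both lowered inhibition modestly. Since here the ring is exchanged rather than decorated, the measured steps give only a loose guide. Compound 4 is therefore expected to stay near compound 1, with an expected step of a number 6 percentage points lower from compound 1 to compound 4 (within the scatter) that may well fall within the scatter. The estimate for compound 4 in this assay is 35%, with a range from 20% to 50%.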

Compound 4, percent growth inhibition at one concentration: 14%
Estimate against measurement, compound 4: 21 percentage points above; the measured number lies below the stated range.
By their numbers in this assay, from the lowest: compounds 4 and 3 (each within the scatter of the next); then compounds 2 and 1 (each within the scatter of the next).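

The ring itself on this saturated chain carbon bound to an oxygen on an aromatic ring proves to matter, not only what sits on it: in this assay, the exchange of phenyl for furan-2-yl gives a number 27 percentage points lower from compound 1 to compound 4 (beyond the scatter), and the exchange of 4-methoxyphenyl for furan-2-yl gives a number 21 percentage points lower from compound 2 to compound 4 (beyond the scatter). Against the 4-nitrophenyl group, the same exchange gives a number 9 percentage points lower from compound 3 to compound 4 (within the scatter), so at this single concentration the furan-2-yl group and the 4-nitrophenyl group cannot be told apart, though both fall clearly short of the unsubstituted phenyl group. No measurement available here accounts for the drop seen with the furan-2-yl group.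

The exchange changes the ring size and introduces a ring oxygen together, so the compounds shown do not separate these two differences. From the compounds shown here alone, a thiophen-2-yl group in the same place would keep the five-membered ring with sulfur in place of oxygen, while a pyridin-2-yl group would keep the six-membered ring and carry a ring nitrogen, and how either would read in this assay remains open.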